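The source may report more compounds than this note shows. Statements on the series, on what has been measured and on what is new or still open speak of the compounds shown alone.

Measured compounds:
compound 1 `CC(=O)Nc1cccc(C2CCN(CCn3c(-c4ccccc4)nc4ccccc43)CC2)c1`: 10000 nM
compound 2 `CC(=O)Nc1cccc(C2CCN(CCCn3c(-c4ccccc4)nc4ccccc43)CC2)c1`: 2 nM

Among the compounds with values here, in an assay for displacement of a labelled ligand from melanin-concentrating hormone receptor 1 (Homo sapiens), read by fluorescence (a higher number here means a weaker inhibitor, a lower number a stronger inhibitor), compound 2 holds the lowest of the two numbers known so far; compound 1 sits at a far higher number, a gap well beyond the scatter. Compound 3 `CC(=O)Nc1cccc(C2CCN(CCCn3c(-c4ccccc4Cl)nc4ccccc43)CC2)c1` carries compound 2 one step further: chloro in place of hydrogen on an aromatic carbon, placed ortho to a large group, so that phenyl becomes 2-chlorophenyl. Within the data shown here, no measured pair shows this change, so its size is unknown from the data; the expected step, a 1.5-fold higher number from compound 2 to compound 3 (0.18 log units; within the scatter), is small, within or near the scatter, with no firm direction. Compound 3 is estimated at 3 nM, with a range from 0.7 nM to 15 nM.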

Compound 3, half-maximal inhibitory concentration: 10 nM
The estimate for compound 3 lay 3.3-fold (0.52 log units) below the measured number; the measured number falls inside the stated range.
By their numbers in this assay, from the lowest: compound 2; then compound 3; then compound 1.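

In this assay, within the data shown here, chloro in place of hydrogen on an aromatic carbon, ortho to a large group, gives a 5.0-fold higher number from compound 2 to compound 3 (0.70 log units; beyond the scatter), the first single-place step that lies on the phenyl rather than the chain. The phenyl therefore responds to a single added atom at this place, though compound 3 still reads 10 nM and the position accepts chloro. No available evidence bears on the reason for this step. As far as these compounds go, whether fluoro, methyl or methoxy at this place would give a smaller or larger step remains open, as does the effect of chloro elsewhere on the phenyl.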